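Aryl swap on the triazole nitrogen: compound 3 to compound 4

The compounds below may be only part of what the source reports. "The series", "measured", "known", "first", "only" and "open" are said of these compounds alone.

Compound 1 `N#CC1=C(N)Oc2c(c3nc4ccccc4nc3c3ccccc23)C12C(=O)N(Cc1cnnn1-c1ccccc1Cl)c1ccccc12` in a functional assay on A549 cells (Homo sapiens) for antiproliferative activity, read by MTT assay, with a stated time of 48 h; a lower number here means a stronger inhibitor, a higher number a weaker inhibitor: 42600 nM
Compound 2 `N#CC1=C(N)Oc2c(c3nc4ccccc4nc3c3ccccc23)C12C(=O)N(Cc1cnnn1-c1ccc(Br)cc1)c1ccccc12` in this assay: 44300 nM
Compound 3 `CCOc1ccc(-n2nncc2CN2C(=O)C3(C(C#N)=C(N)Oc4c(N)cc5nc6ccccc6nc5c43)c3ccccc32)cc1` in this assay: > 50000 nM, which is a limit of the assay and not a number.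

Compound 3 thus stands at the limit of > 50000 nM in this assay, at which 1 of the 3 values shown sits, and whether it sits within the scatter of compounds 1 and 2 or beyond them cannot be read from a limit. Compounds 1 and 2 share one core; compound 3 has a different core, and compound 4 `Cc1ccc(Cl)cc1-n1nncc1CN1C(=O)C2(C(C#N)=C(N)Oc3c(N)cc4nc5ccccc5nc4c32)c2ccccc21` keeps that core of compound 3.

Compound 4 differs from compound 3 by 5-chloro-2-methylphenyl in place of 4-ethoxyphenyl on an aromatic nitrogen.

Among the compounds with values here, the one measured step that bears on this change is a 1.0-fold higher number from compound 1 to compound 2 (0.02 log units; within the scatter), also an exchange of the aryl group on the aromatic nitrogen, and it stayed within the scatter. On that basis no step beyond the scatter is expected for a step that the limit leaves unreadable from compound 3 to compound 4, in either direction. Compound 4 is therefore expected to come out at or near the limit again, with the estimate for compound 4 put at 60000 nM, in the range 30000 nM to 150000 nM, and with a fair chance that only a limit is reported.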

Compound 4, half-maximal inhibitory concentration: > 50000 nM
Compound 4 ended at the assay's limit (the forecaster's own chance of this, stated with the estimate: 65%); the middle value is on the limit's open side.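

In this assay, within the data shown here, compound 3 and compound 4 both end at a limit of the assay and not at a number, so no step between them can be read: the limit of > 50000 nM in this assay, at which 2 of the 4 values shown sit.

The compounds shown leave open whether any aryl group on the aromatic nitrogen of the core of compound 3 gives a readable value in this assay.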